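This account rests on a few compounds, and the source may have more. Where it says the series, first, only, none or still open, it means among the compounds named here.

Measured so far:
Compound 1 `COC(=O)CCC(NC(=O)[C@@H]1CCC(=O)N1)C(=O)N1CCC[C@H]1C(N)=O`: 0.333 h
Compound 2 `CCCCCCOC(=O)CCC(NC(=O)[C@@H]1CCC(=O)N1)C(=O)N1CCC[C@H]1C(N)=O`: 0.367 h

In an ADME assay on the whole organism (brain) for pharmacokinetics, with Mus musculus as the target (on this read-out lower numbers stand for a shorter-lived compound and higher numbers for a longer-lived compound), compound 2 gives 0.367 h and stands within the scatter of compound 1, which gives 0.333 h. Compound 3 `NC(=O)[C@@H]1CCCN1C(=O)C(CCC(=O)OC1CCCCC1)NC(=O)[C@@H]1CCC(=O)N1` has not yet been measured. It carries cyclohexyl in place of hexyl on an oxygen next to a carbonyl group. Within the data shown here, one measured step bears on this change: a 1.1-fold higher number from compound 1 to compound 2 (0.04 log units; within the scatter). That step also alters the chain on the oxygen, and it lies within the scatter. Among the measured compounds shown here, no measured compound has a ring at this place, so the data give no direction for the change. On the evidence of that one small step, the expected move is no larger than the scatter, with the estimated step being a 1.0-fold lower number from compound 2 to compound 3 (0.02 log units; within the scatter). For compound 3 the estimated half-life is 0.35 h, with an expected range from 0.2 h to 0.6 h.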

Compound 3, half-life: 0.417 h
Beside the measured number, compound 3's estimate is 1.2-fold (0.08 log units) below it, within the range that was stated.
By their numbers in this assay, from the lowest: compounds 1, 2 and 3 (each within the scatter of the next).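

In this assay, the first ring at this position, cyclohexyl in place of hexyl on an oxygen next to a carbonyl group, gives a 1.1-fold higher number from compound 2 to compound 3 (0.06 log units; within the scatter). Cyclohexyl in place of methyl gives a 1.3-fold higher number from compound 1 to compound 3 (0.10 log units; within the scatter), so the finding that had rested on two open chains now extends to a ring: methyl, hexyl and cyclohexyl on this oxygen all lie within the scatter of one another. Nothing shown offers an explanation for this result. The compounds shown leave open whether a group of another kind on this oxygen, such as benzyl or an aminoethyl chain, would give a step beyond the scatter. They also leave open whether the free carboxylic acid would do so.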